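A few compounds are considered here, and "the series" means these few. Any claim that something is new, unique, unknown or untested is made for them only; others in the source may bear on it.

compound 1 `N#CCC(=O)N/N=C1\C(=O)Nc2ccc(S(=O)(=O)N3CCOCC3)cc21` gives 27700 nM
compound 2 `Cc1ccc(/N=C2\C(=O)Nc3ccc(S(=O)(=O)N4CCOCC4)cc32)cc1` gives 55900 nM
compound 3 `Cc1ccc(S(=O)(=O)N/N=C2\C(=O)Nc3ccc(S(=O)(=O)N4CCOCC4)cc32)cc1` gives 38400 nM

All three values come from a functional assay on MCF7 cells (Homo sapiens) for cytotoxicity, read by sulforhodamine B assay, with a stated time of 24 h (a higher number here means a weaker inhibitor, a lower number a stronger inhibitor), and all lie within the scatter of one another. Compound 3 at 38400 nM sits inside this tight group, with no clear separation from compound 1 or compound 2.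

The change from compound 3 to compound 4 `N/N=C1\C(=O)Nc2ccc(S(=O)(=O)N3CCOCC3)cc21` is hydrogen in place of (4-methylphenyl)sulfonyl on an amine nitrogen. Going by the values given here, two measured steps bear on it. The closer one is a 1.4-fold higher number from compound 1 to compound 3 (0.14 log units; within the scatter), which swaps (cyanomethyl)carbonyl for (4-methylphenyl)sulfonyl on that same amine nitrogen. The other is a 2.0-fold higher number from compound 1 to compound 2 (0.30 log units; within the scatter), which replaces the whole ((cyanomethyl)carbonyl)amino with 4-methylphenyl on a double-bonded nitrogen. Among the compounds with values here, no measured compound carries hydrogen at this place, so the change itself is untested.

Within the data shown here, with these steps as the only guide, no step beyond the scatter is expected in this assay here. The expected size is a 1.1-fold lower number from compound 3 to compound 4 (0.04 log units; within the scatter), an estimate with no clear direction. For compound 4 the estimated value is 35000 nM, with an expected range of 14000 nM to 85000 nM for a measurement.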

Compound 4, half-maximal inhibitory concentration: 46800 nM
Compound 4: the middle estimate sits 1.3-fold (0.13 log units) below what was measured; the measured number falls inside the stated range.
By their numbers in this assay, from the lowest: compounds 1, 3, 4 and 2 (each within the scatter of the next).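

In this assay, hydrogen in place of (4-methylphenyl)sulfonyl on the amine nitrogen gives a 1.2-fold higher number from compound 3 to compound 4 (0.09 log units; within the scatter) and so adds the unsubstituted case at this position, while hydrogen in place of (cyanomethyl)carbonyl gives a 1.7-fold higher number from compound 1 to compound 4 (0.23 log units; within the scatter) on the same nitrogen. Amino in place of 4-methylphenyl on the double-bonded nitrogen gives a 1.2-fold lower number from compound 2 to compound 4 (0.08 log units; within the scatter) as well, so all three new steps stay within the scatter, and neither the loss of the (4-methylphenyl)sulfonyl with its aromatic ring nor the loss of the (cyanomethyl)carbonyl separates compound 4 from its neighbours. Nothing available explains this flat result.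

Going by these compounds, whether a carboxylic acid or a longer alkyl chain on this amine nitrogen would give a step beyond the scatter remains open. The three steps also leave open whether any change at this position matters in other cell lines or at other exposure times.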